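The source may report more compounds than this note shows. Statements on the series, on what has been measured and on what is new or still open speak of the compounds shown alone.

Among the compounds with values here, in a functional assay on MCF7 cells (Homo sapiens) for antiproliferative activity, read by MTT assay, with a stated time of 72 h (a lower number here means a stronger inhibitor, a higher number a weaker inhibitor), compound 1 `COc1ccc(/C=C2\S/C(=N\c3ccc(Cl)cc3)N(C)C2=O)cc1` gives 39300 nM, the only actual number in this small series so far. Compound 2 `C=C1CN(C)/C(=N/c2ccccc2)S1` gives > 100000 nM, which is a limit of the assay and not a number. Compound 2 therefore offers no measured size of effect to build on.

The next structure is compound 3 `COc1ccc(/C=C2\S/C(=N\c3ccc(C)cc3)N(C)C2=O)cc1`, which keeps the core of compound 1 and differs at one place: methyl in place of chloro on an aromatic carbon. This puts methyl in place of chloro on an aromatic carbon, para to a large group.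

Within the data shown here, no measured pair tests this change, so the estimate rests on compound 1 at 39300 nM. In this assay, the expected size of a 1.1-fold higher number from compound 1 to compound 3 (0.03 log units; within the scatter) is none beyond the scatter, with no direction favoured. For compound 3 the estimated value is 42000 nM, with an expected range of 17000 nM to 100000 nM.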

Compound 3, half-maximal inhibitory concentration: > 100000 nM
Compound 3: no number, only a limit; the forecaster's own chance of this, stated with the estimate: 15%; middle value at least 2.3-fold (0.37 log units) from the limit.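

In this assay, the position on the aromatic carbon para to a large group is not indifferent: going from 4-chlorophenyl to 4-methylphenyl gives an at least 2.5-fold higher number from compound 1 to compound 3 (0.40 log units; beyond the scatter). Within the data shown here, this is the first measured step, and it shows that a change of a single heavy atom on the shared core is enough to lose the one measurable number. Compound 3 gives a limit and not a number, so the step has a lower bound only and its full size stays open: the limit of > 100000 nM in this assay, at which 2 of the 3 values shown sit.

With only chloro and methyl at this position, the compounds shown do not reveal what the step depends on. A bromo, methoxy or trifluoromethyl group there, or an amine, would show whether the number of compound 1 can be lowered or whether chloro stands alone.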